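Amine side chain: from compound 2 to compound 3

A few compounds are considered here, and "the series" means these few. Any claim that something is new, unique, unknown or untested is made for them only; others in the source may bear on it.

Going by the values given here, in a functional assay on HL60/MX2 cells (Homo sapiens) for antiproliferative activity, read by MTT assay, with a stated time of 48 h (on this read-out higher numbers stand for weaker inhibition and lower numbers for stronger inhibition), compound 2 (`CCN(CC)CCCn1c(N)c(-c2nc3cc(Cl)ccc3[nH]2)c2nc(C#N)c(C#N)nc21`) gives 2460 nM, the only true number so far. Compound 1 (`CN(C)CCn1c(N)c(-c2nc3cc(Cl)ccc3[nH]2)c2nc(C#N)c(C#N)nc21`) reads > 50000 nM, which is a limit of the assay.

Compound 3 (`CN(C)CCCCn1c(N)c(-c2nc3cc(Cl)ccc3[nH]2)c2nc(C#N)c(C#N)nc21`) differs from compound 2 by (dimethylamino)methyl in place of diethylamino on a saturated chain carbon, three bonds along the chain from an aromatic nitrogen: 3-(diethylamino)propyl gives way to 4-(dimethylamino)butyl.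

Among the compounds with values here, one measured step bears on this: an at least 20-fold lower number from compound 1 to compound 2 (1.30 log units; beyond the scatter). This large step changed the chain and the amine together, so it cannot separate them. Compound 3 keeps the dimethylamino end of compound 1 but not its 2-(dimethylamino)ethyl chain, so the two changes may pull in opposite directions.

The expected result is no step beyond the scatter, with a slight lean to a higher number: a 1.6-fold higher number from compound 2 to compound 3 (0.21 log units; within the scatter). For compound 3 the estimate is 4000 nM, with an expected range of 1000 nM to 20000 nM.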

Compound 3, half-maximal inhibitory concentration: 580 nM
The estimate for compound 3 lay 6.9-fold (0.84 log units) above the measured number; the measured number lies below the stated range.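

With the dimethylamino end held constant, the 4-(dimethylamino)butyl chain separates chain length from the amine, which the first step could not do: in this assay there is an at least 86-fold lower number from compound 1 to compound 3 (1.93 log units; beyond the scatter). Compound 1 stands at a limit of the assay, so the size of that step is only a bound: the limit of > 50000 nM in this assay, at which 1 of the 3 values shown sits A dimethylamino end is therefore compatible with the lowest true number in the series, as a 4.2-fold lower number from compound 2 to compound 3 (0.63 log units; beyond the scatter) shows, although that step changes chain length and amine together.

From the compounds shown here alone, the separate shares of chain and amine in that last step remain open, and 3-(dimethylamino)propyl or 4-(diethylamino)butyl would divide them. Also open, going by these compounds, is whether the trend continues with a longer chain such as 5-(dimethylamino)pentyl, or holds with a cyclic amine such as pyrrolidine or morpholine at the chain end.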